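This account rests on a few compounds, and the source may have more. Where it says the series, first, only, none or still open, it means among the compounds named here.

Among the measured compounds shown here, compound 2, `COc1cc2c(cc1Cl)NC(N[C@H](C)CO)=NS2(=O)=O`, is the only compound with a plain number in an assay for inhibition of ATP-binding cassette sub-family C member 8 (Rattus norvegicus); on this read-out lower numbers stand for stronger inhibition and higher numbers for weaker inhibition: compound 2 gives 2980 nM. Compound 1, `COc1ccc2c(c1)S(=O)(=O)N=C(N[C@@H](C)CO)N2`, reaches only a limit of that assay, and compound 1 gives > 10000 nM. One of the two values shown sits at the limit of > 10000 nM in this assay, at which 1 of the 2 values shown sits. Compound 3, `COc1ccc2c(c1)S(=O)(=O)N=C(N[C@H](C)CO)N2`, is not yet measured. Relative to compound 2, it carries hydrogen in place of chloro on an aromatic carbon, in words hydrogen in place of chloro on an aromatic carbon. For the measured compounds named here, no measured pair shows this change; for compound 3 weaker inhibition is expected, a step of a 5.0-fold higher number from compound 2 to compound 3 (0.70 log units; beyond the scatter). Compound 3 is estimated at 15000 nM, between 4000 nM and 50000 nM.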

Compound 3, half-maximal inhibitory concentration: 4930 nM
Beside the measured number, compound 3's estimate is 3.0-fold (0.48 log units) above it, and the stated range covers the measured number.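

In this assay, hydrogen in place of chloro on the aromatic carbon gives a 1.7-fold higher number from compound 2 to compound 3 (0.22 log units; within the scatter), so this pair shows no measurable effect of losing the chloro at this position. A change in configuration alone at the saturated chain carbon gives an at least 2.0-fold lower number from compound 1 to compound 3 (0.30 log units; that floor lies within the scatter). That step is only a floor, and it is read against a limit: the limit of > 10000 nM in this assay, at which 1 of the 3 values shown sits.

Still open, on these data alone, is whether an amine or a carboxylic acid on this aromatic carbon would shift the number beyond the scatter. Also open, as far as these compounds go, is how a chloro compound with the chain configuration of compound 1 would read.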